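Pyridin-2-yl replaces 3,5-dichlorophenyl on a sulfonamide nitrogen

A few compounds are considered here, and "the series" means these few. Any claim that something is new, unique, unknown or untested is made for them only; others in the source may bear on it.

For the measured compounds named here, in a functional assay on J774 cells (Mus musculus) for cytotoxicity (a lower number here means a stronger inhibitor, a higher number a weaker inhibitor), compound 1 (`CCCN(CCC)c1c([N+](=O)[O-])cc(S(=O)(=O)Nc2cccc(OC)c2)cc1[N+](=O)[O-]`) gives 25000 nM and compound 2 (`CCCN(CCC)c1c([N+](=O)[O-])cc(S(=O)(=O)Nc2cc(Cl)cc(Cl)c2)cc1[N+](=O)[O-]`) gives 5100 nM as the lower of the two numbers so far. Compound 3 (`CCCN(CCC)c1c([N+](=O)[O-])cc(S(=O)(=O)Nc2ccccn2)cc1[N+](=O)[O-]`) carries pyridin-2-yl in place of 3,5-dichlorophenyl on a sulfonamide nitrogen. Going by the values given here, one measured step bears on this change, also on a sulfonamide nitrogen, and the expectation rests on it alone: a 4.9-fold lower number from compound 1 to compound 2 (0.69 log units; beyond the scatter) with 3,5-dichlorophenyl entering. Among the compounds with values here, compound 3 gives up that group, and no measured compound carries pyridin-2-yl, so the reading is uncertain. A move of similar size back to a higher number in this assay is expected, and the estimated step is a 4.9-fold higher number from compound 2 to compound 3 (0.69 log units; beyond the scatter) on this reading. Compound 3 is estimated at 25000 nM with a range from 9000 nM to 70000 nM as the expected span.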

Compound 3, half-maximal inhibitory concentration: 45000 nM
Estimate against measurement, compound 3: 1.8-fold (0.26 log units) below; the measured number falls inside the stated range.
By their numbers in this assay, from the lowest: compound 2; then compounds 1 and 3 (each within the scatter of the next).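

Putting pyridin-2-yl on the sulfonamide nitrogen gives an 8.8-fold higher number from compound 2 to compound 3 (0.95 log units; beyond the scatter) in this assay and so removes the advantage of compound 2 with a second, unrelated group. For the compounds shown here, the comparison with 3-methoxyphenyl gives a 1.8-fold higher number from compound 1 to compound 3 (0.26 log units; within the scatter) and so does not separate these two groups at this position, which leaves 3,5-dichlorophenyl as the one group of the three set apart from both others by steps beyond the scatter. Nothing available explains why this position responds in this way.

Open, going by these compounds, is whether the lower number of compound 2 follows the chlorine atoms or the ring of carbon only, which a plain phenyl or a 3-chlorophenyl group on the sulfonamide nitrogen would help to separate. Also open, on these data alone, is whether 3,5-dimethylphenyl or 3,5-bis(trifluoromethyl)phenyl would do the same as 3,5-dichlorophenyl.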